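The source may report more compounds than this note shows. Statements on the series, on what has been measured and on what is new or still open speak of the compounds shown alone.

Working notes on the series in a functional assay on U-87MG ATCC cells for cytotoxicity against U-87 MG (Homo sapiens), read by MTT assay, with a stated time of 48 h; a lower number here means a stronger inhibitor, a higher number a weaker inhibitor. Compound 1 `O=C(O[C@H]1C[C@H](n2cc(F)c(=O)[nH]c2=O)O[C@@H]1COP(=O)(O)Oc1ccc2ncccc2c1)c1ccccc1` gives 880 nM there. Compound 2 `C[n+]1cccc(OP(=O)([O-])OC[C@H]2O[C@@H](n3cc(F)c(=O)[nH]c3=O)C[C@@H]2OC(=O)c2ccccc2)c1` gives 590 nM in this assay. Compound 3 `CCCCCCCCCC[n+]1cccc(OP(=O)([O-])OC[C@H]2O[C@@H](n3cc(F)c(=O)[nH]c3=O)C[C@@H]2OC(=O)c2ccccc2)c1` gives 670 nM in this assay and stands second highest of the three numbers; its nearest neighbour is compound 2 and its furthest is compound 1, and both gaps lie within the scatter, so the three values cannot be ordered against one another.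

Going by the values given here, the one step measured at the saturated chain carbon bound to the aromatic nitrogen is a 1.1-fold higher number from compound 2 to compound 3 (0.06 log units; within the scatter), nonyl in place of hydrogen, a change that left the number within the scatter.

Compound 4 `O=C(O[C@H]1C[C@H](n2cc(F)c(=O)[nH]c2=O)O[C@@H]1COP(=O)([O-])Oc1ccc[n+](Cc2ccccc2)c1)c1ccccc1` is the next member. Relative to compound 3 it carries phenyl in place of nonyl on a saturated chain carbon bound to an aromatic nitrogen. The step from compound 2 to compound 3 is the only one that bears on this position, and it showed that a large change to the group on that carbon moved the number by no more than the scatter. On that basis the step is expected to be a 1.0-fold lower number from compound 3 to compound 4 (0.01 log units; within the scatter), with no direction beyond the scatter. Compound 4 is therefore estimated at 650 nM in this assay, with a range of 350 nM to 1200 nM.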

Compound 4, half-maximal inhibitory concentration: 660 nM
Estimate against measurement, compound 4: 1.0-fold (0.01 log units) below, and the stated range covers the measured number.
By their numbers in this assay, from the lowest: compounds 2, 4, 3 and 1 (each within the scatter of the next).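

At the saturated chain carbon bound to the aromatic nitrogen, a ring now stands in this assay where only hydrogen and a saturated chain stood before. Phenyl in place of nonyl gives (a 1.0-fold lower number from compound 3 to compound 4 (0.01 log units; within the scatter)), and phenyl in place of hydrogen gives (a 1.1-fold higher number from compound 2 to compound 4 (0.05 log units; within the scatter)). The insensitivity seen with nonyl alone therefore extends to a six-membered aromatic ring of carbon only, and hydrogen, nonyl and phenyl on this carbon all give numbers within the scatter of one another. No information is available on why the number holds steady across these groups at this place.

As far as these compounds go, it remains open whether this tolerance would survive a group carrying an amine, a carboxylic acid or a hydroxyl on that carbon, or a chain longer than nonyl. Also open is whether the number would stay as steady in these compounds if the benzoate ester on the shared core gave way to an acetate ester or a free hydroxyl, since every step shown here leaves that part of the structure unchanged.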